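The compounds below may be only part of what the source reports. "The series", "measured", "known", "first", "only" and "open" are said of these compounds alone.

Among the three compounds measured here, compound 3 `NC(=O)c1c(NC(=O)c2ccccc2I)sc2c1CCN(C(=S)Nc1ccccc1Br)C2` gives the highest number in a functional assay on MKN-74 cells (Homo sapiens) for antiproliferative activity, with a stated time of 24 h (on this read-out lower numbers stand for stronger inhibition and higher numbers for weaker inhibition), at 22400 nM. Compound 2 `NC(=O)c1c(NC(=O)c2ccccc2I)sc2c1CCN(C(=S)Nc1ccccc1Cl)C2` stands nearest with 17500 nM, and the step of a 1.3-fold higher number from compound 2 to compound 3 (0.11 log units; within the scatter) lies within the scatter. Compound 1 `NC(=O)c1c(NC(=O)c2ccccc2Cl)sc2c1CCN(C(=S)Nc1ccccc1C(F)(F)F)C2` stands furthest, at 1870 nM. Compound 4 `NC(=O)c1c(NC(=O)c2ccccc2I)sc2c1CCN(C(=S)Nc1ccccc1C(F)(F)F)C2` differs from compound 3 by trifluoromethyl in place of bromo on an aromatic carbon. Going by the values given here, no measured step swaps these two groups directly; compound 1 carries the same trifluoromethyl but differs from compound 3 in a second place as well, so its value can only hint that the number may fall. Compound 4 is therefore expected to give a somewhat lower number, a 2.8-fold lower number from compound 3 to compound 4 (0.45 log units; beyond the scatter), with wide uncertainty. The estimate for compound 4 is 8000 nM, in a range from 2500 nM to 25000 nM.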

Compound 4, half-maximal inhibitory concentration: 14200 nM
Estimate against measurement, compound 4: 1.8-fold (0.25 log units) below, within the range that was stated.
By their numbers in this assay, from the lowest: compound 1; then compounds 4, 2 and 3 (each within the scatter of the next).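

In this assay, trifluoromethyl on this aromatic carbon cannot be told apart from bromo (a 1.6-fold lower number from compound 3 to compound 4 (0.20 log units; within the scatter)) or from chloro (a 1.2-fold lower number from compound 2 to compound 4 (0.09 log units; within the scatter)) when iodo sits in the other place. Going from one heavy atom to four here thus brings no readable change. The clear gap comes from the other place, where chloro gives way to iodo (a 7.6-fold higher number from compound 1 to compound 4 (0.88 log units; beyond the scatter)). On these data alone, whether a methyl or methoxy group at this position would behave the same stays open. Nothing shown gives a reason for these numbers.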